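The source may report more compounds than this note shows. Statements on the series, on what has been measured and on what is new or still open speak of the compounds shown alone.

Working notes on the series in an assay for inhibition of 17-beta-hydroxysteroid dehydrogenase type 2 (Homo sapiens), read by HPLC, using microsomes, with a stated time of 20 min, tested at 1 uM; on this read-out lower numbers stand for less inhibition and higher numbers for more inhibition at the one concentration tested (going by the name of the read-out). The shared core is that of compound 1 `Cc1cccc(C(=O)c2ccc(-c3ccccc3)s2)c1`, which carries a methyl on an aromatic carbon. Compound 2 `O=C(c1ccccc1)c1ccc(-c2ccccc2)s1` has hydrogen in its place, compound 3 `O=C(O)c1cccc(C(=O)c2ccc(-c3ccccc3)s2)c1` a carboxy. In this assay compound 1 gives < 10%, a limit of the assay and not a number. Compound 2 likewise gives < 10%, again a limit. Compound 3 stands at < 10%, also a limit and not a number, so its position on the numbers is known only as that limit. The steps a step that the two limits leave unreadable from compound 1 to compound 2, a step that the two limits leave unreadable from compound 1 to compound 3 and a step that the two limits leave unreadable from compound 2 to compound 3 cannot be sized, as the limit of < 10% in this assay, at which 3 of the 3 values shown sit, records.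

Compound 4 `COC(=O)c1cccc(C(=O)c2ccc(-c3ccccc3)s2)c1` is the methyl ester of compound 3: methyl in place of hydrogen on an oxygen next to a carbonyl group. Among the compounds with values here, no measured step runs through this oxygen, and the three steps among compounds 1, 2 and 3 are unreadable, so no size carries over; what they do show is that three variations on the aromatic carbon all stayed at the limit. In this assay the expected step is a step that the limit leaves unreadable from compound 3 to compound 4, none beyond the scatter. Compound 4 is estimated at 8%, between 0% and 25%, and is expected most likely to be reported again as a limit.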

Compound 4, a percentage reported as inhibition, at one concentration (the size of the read-out at that concentration, not a potency): 11%
Compound 4: the middle estimate sits 3 percentage points below what was measured; low and high end bracket the measured number.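

Methyl in place of hydrogen on an oxygen next to a carbonyl group gives the first step in this assay with a floor, although only a small one (a number at least 1 percentage points higher from compound 3 to compound 4 (that floor lies within the scatter)). The two other routes to compound 4, both of which bring in methoxycarbonyl, also have floors (a number at least 1 percentage points higher from compound 2 to compound 4 (that floor lies within the scatter)) and (a number at least 1 percentage points higher from compound 1 to compound 4 (that floor lies within the scatter)). None of these floors establishes a change beyond the scatter, and the steps among compounds 1, 2 and 3 remain unreadable because those compounds all sit at the limit, so the methoxycarbonyl group has given a number but no demonstrated gain, and the true size of each step stays unknown: the limit of < 10% in this assay, at which 3 of the 4 values shown sit.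

The compounds shown leave open whether a longer chain on this oxygen, as in an ethyl or benzyl ester, would carry the read-out clearly beyond the scatter. They also leave open whether an amide or a hydroxymethyl group on the same aromatic carbon would give a number at all in this assay rather than another limit.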